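Bromo in Place of Chloro on a Shared Core

The source may hold more compounds than are shown below. What is called first, only, known or untested is meant among the compounds shown, and "the series" means these compounds.

Of the compounds shown here, three with a shared core have been measured. In an assay on isolated protein for inhibition of Amine oxidase [flavin-containing] B (Homo sapiens) (a higher number here means a weaker inhibitor, a lower number a stronger inhibitor), compound 1 `C#CCNC1CCc2c(SCCc3cccc(Br)c3)cccc21` gives 30500 nM, and compound 2 `C#CCNC1CCc2c(SCCc3cccc(Cl)c3)cccc21` gives 82400 nM. These two differ in one place, (bromo in place of chloro on an aromatic carbon), and the measured step is a 2.7-fold lower number from compound 2 to compound 1 (0.43 log units; beyond the scatter). Compound 3 `C#CCNC1CCc2c(SCc3cccc(Cl)c3)cccc21` gives 23300 nM in this assay; how its core differs from that of compound 2 is not broken down here. Compound 4 `C#CCNC1CCc2c(SCc3cccc(Br)c3)cccc21` has not yet been measured and differs from compound 3 by bromo in place of chloro on an aromatic carbon, the same change as that between compound 2 and compound 1. A comparable step is expected, a 2.1-fold lower number from compound 3 to compound 4 (0.33 log units; beyond the scatter), resting on the measured step of a 2.7-fold lower number from compound 2 to compound 1 (0.43 log units; beyond the scatter) and on the value of compound 3. Compound 4 is accordingly estimated at 11000 nM, with a range from 4500 nM to 28000 nM.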

Compound 4, half-maximal inhibitory concentration: > 100000 nM
Compound 4 was reported as a limit; the forecaster's own chance of this, stated with the estimate: 3%; middle value at least 9.0-fold (0.95 log units) from the limit.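

In this assay, bromo in place of chloro gives an at least 4.2-fold higher number from compound 3 to compound 4 (0.63 log units; beyond the scatter). The change therefore does not carry from one core to the other, not even in direction: the same change on two cores in this assay, a 2.7-fold lower number (0.43 log units; beyond the scatter) from compound 2 to compound 1 and an at least 4.2-fold higher number (0.63 log units; beyond the scatter) from compound 3 to compound 4, at least 11-fold (1.06 log units) apart, beyond the scatter of two such steps. On these data alone, compound 4 is reported only as a limit, > 100000 nM, so the true size of its step stays unknown, and two pairs cannot show what in the cores separates them or how a further core would respond.

The compounds shown leave open whether fluoro or methoxy in the same place would also behave differently on the two cores. They also leave open whether an ether oxygen in place of the sulfur would alter the outcome.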